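Cytotoxicity notes on a triazolyl-aryl sulfonamide series

A few compounds are considered here, and "the series" means these few. Any claim that something is new, unique, unknown or untested is made for them only; others in the source may bear on it.

Measured so far:
Compound 1 `Cc1cccc(-n2cc(-c3ccc(NS(=O)(=O)c4c[nH]c(=O)[nH]c4=O)cc3)nn2)c1` — 28300 nM
Compound 2 `Cc1ccc(-n2cc(-c3ccc(NS(=O)(=O)c4c[nH]c(=O)[nH]c4=O)cc3)nn2)cc1` — "not toxic" (no number reported) (no number reported)

Both compounds were run in an ADME assay on GES1 cells (Homo sapiens) for cytotoxicity, read by MTT assay, with a stated time of 24 h; on this read-out lower numbers stand for higher toxicity in this test and higher numbers for lower toxicity in this test. Compound 1 gives 28300 nM, a weak effect in this assay. For compound 2 the record in this assay reads only "not toxic" (no number reported), so compound 2 stands without a single number; nothing more can be said of where compound 2 lies relative to compound 1 than that neither shows marked toxicity in this assay.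

Compound 3 `O=c1[nH]cc(S(=O)(=O)Nc2ccc(-c3cn(-c4ccccc4F)nn3)cc2)c(=O)[nH]1` is not yet measured. It differs from compound 2 by 2-fluorophenyl in place of 4-methylphenyl on an aromatic nitrogen. Going by the values given here, no step between measured compounds is available for this change, so its effect in this assay is unknown; given that both measured compounds sit in the weakly toxic range, no shift beyond the usual scatter is expected in either direction.

Compound 3 is therefore expected to give about 30000 nM in this assay, with a plausible range from 10000 nM to 100000 nM, and a fair chance that only a limit is reported.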

Compound 3, half-maximal cytotoxic concentration: > 100000 nM
Compound 3 was reported as a limit; the forecaster's own chance of this, stated with the estimate: 40%; at least 3.3-fold (0.52 log units) between middle value and limit.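

On the aromatic nitrogen of the five-membered ring, the aryl group now gives a readable shift in this assay: 2-fluorophenyl in place of 3-methylphenyl gives an at least 3.5-fold higher number from compound 1 to compound 3 (0.54 log units; beyond the scatter). Going by these compounds alone, compound 3 is reported only as a limit of the assay and not as a number: the limit of > 100000 nM in this assay, at which 1 of the 3 values shown sits. Compound 2, recorded only as not toxic, offers no number to set against this result, so the shift toward lower toxicity in this test rests on the single step from the 3-methylphenyl compound.

Going by these compounds, that step changes both the substituent and where it sits on the phenyl ring, so the separate contributions of removing the methyl and introducing the fluorine remain open. Also open, on these data alone, is how this assay would read for a phenyl group carrying an amine or a carboxylic acid at this position, or for a longer alkyl chain in place of the methyl, and whether the higher number seen here would hold for any of these groups.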